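Drawing the Stereocentres of Compound 2

This account rests on a few compounds, and the source may have more. Where it says the series, first, only, none or still open, it means among the compounds named here.

compound 1 `CCCN(CC1CCOC1)C(=O)c1cc(OC)c2oc(NCc3cccc(Cl)c3)nc2c1`: 65 mL/min/kg
compound 2 `COc1cc(C(=O)N2CCC(O)C(C)C2)cc2nc(NCc3cccc(Cl)c3)oc12`: 45 mL/min/kg

In an ADME assay on cells (Hepatocyte, Rattus norvegicus, strain Wistar) for pharmacokinetics, read by LC-MS, with a stated time of 90 min, tested at 1 uM (a lower number here means slower removal, a higher number faster removal of the compound), compound 2 gives 45 mL/min/kg, which stands within the scatter of compound 1. Among the compounds with values here, the one measured step, a 1.4-fold lower number from compound 1 to compound 2 (0.16 log units; within the scatter), puts 4-hydroxy-3-methylpiperidin-1-yl in place of ((oxolan-3-yl)methyl)(propyl)amino on a carbonyl carbon.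

Compound 3 `COc1cc(C(=O)N2CC[C@@H](O)[C@H](C)C2)cc2nc(NCc3cccc(Cl)c3)oc12` follows from compound 2 with no group leaving or entering: the two compounds have the same atoms and bonds; at least one stereo element is drawn with a configuration in one of them and without one in the other: 2 of 2 stereo elements differ; a stereocentre at a saturated ring carbon is drawn without a configuration in compound 2 and R in compound 3; a stereocentre at a saturated ring carbon is drawn without a configuration in compound 2 and R in compound 3. Both stereocentres at saturated ring carbons are drawn R in compound 3 and without a configuration in compound 2.

Within the data shown here, the measured step concerns a different change and stayed within the scatter, and no measured pair tests a drawn configuration. The data therefore give no direction. The expected step is no change at the digits printed from compound 2 to compound 3 (within the scatter), none beyond the scatter. For compound 3 the estimated clearance is 45 mL/min/kg, with an expected range from 27 mL/min/kg to 70 mL/min/kg.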

Compound 3, clearance: 38.3 mL/min/kg
The estimate for compound 3 lay 1.2-fold (0.07 log units) above the measured number, and the stated range covers the measured number.
By their numbers in this assay, from the lowest: compounds 3, 2 and 1 (each within the scatter of the next).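

In this assay, within the data shown here, compound 3 gives the first reading of a drawn configuration on the 4-hydroxy-3-methylpiperidin-1-yl group, with both stereocentres R, and this stays within the scatter (a 1.2-fold lower number from compound 2 to compound 3 (0.07 log units; within the scatter)). Set against the ((oxolan-3-yl)methyl)(propyl)amino amide, the form with drawn stereocentres also stays within the scatter (a 1.7-fold lower number from compound 1 to compound 3 (0.23 log units; within the scatter)). The step to compound 3 therefore does not compare two defined configurations, because of one limit in the pair: the fact that one of compounds 2 and 3 is drawn with a defined configuration and the other without, at the place where they differ.

The compounds shown leave open how forms with S at either stereocentre would read in this assay. Also open, as far as these compounds go, is whether a morpholine amide, or a methoxy group in place of the hydroxyl on the piperidine, would move the clearance beyond the scatter.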